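Moving the halogen on the aryl ring of compound 3

The compounds below may be only part of what the source reports. "The series", "measured", "known", "first", "only" and "open" are said of these compounds alone.

Compound 3 `Cc1nc2c([nH]1)C(=O)/C(=N/c1ccc(I)cc1)C(Cl)=C2O` sits at the low end of three numbers in a functional assay on NIH3T3 cells (Mus musculus) for antiproliferative activity; a higher number here means a weaker inhibitor, a lower number a stronger inhibitor: compound 3 gives 600 nM, while compound 2 `Cc1nc2c([nH]1)C(=O)/C(=N/c1ccc(C(F)(F)F)cc1)C(Cl)=C2O` gives 1100 nM and compound 1 `Cc1nc2c([nH]1)C(=O)/C(=N/c1ccc(Cl)cc1Cl)C(Cl)=C2O` gives 1200 nM, both within the scatter of compound 3. Compound 4 `Cc1nc2c([nH]1)C(=O)/C(=N/c1cccc(Cl)c1)C(Cl)=C2O` carries 3-chlorophenyl in place of 4-iodophenyl on a double-bonded nitrogen. Within the data shown here, the only measured step that touches the aryl group, a 1.8-fold lower number from compound 2 to compound 3 (0.26 log units; within the scatter), stayed within the scatter, and the values of compound 1 and compound 3 also lie within it. A step of similar size is therefore expected from compound 3 to compound 4, a 1.5-fold higher number from compound 3 to compound 4 (0.18 log units; within the scatter), with no clear direction. Compound 4 is estimated at 900 nM in this assay, in the range 400 nM to 2000 nM.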

Compound 4, half-maximal inhibitory concentration: 1600 nM
The estimate for compound 4 lay 1.8-fold (0.25 log units) below the measured number; low and high end bracket the measured number.
By their numbers in this assay, from the lowest: compounds 3, 2, 1 and 4 (each within the scatter of the next, the first and the last beyond it).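

In this assay, among these compounds, a 2.7-fold higher number from compound 3 to compound 4 (0.43 log units; beyond the scatter) is the only step at this aryl group that lies beyond the scatter, so the group does not tolerate every change equally. The step is modest, and the halogen and its place on the ring change together, so the two cannot be told apart here. No available evidence accounts for the step. The compounds shown leave open how 4-chlorophenyl or 3-iodophenyl would compare, which would separate those two changes. They also leave open whether an amine or a carboxylic acid on the ring would be tolerated.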